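A Urea Swap on a Benzazocine Amide Scaffold

A few compounds are considered here, and "the series" means these few. Any claim that something is new, unique, unknown or untested is made for them only; others in the source may bear on it.

Two compounds share a common core and differ in the group on the urea nitrogen. Compound 1 `Cc1cc(C(=O)N2CCCCc3ccccc32)cc(C)c1CNC(=O)Nc1c(F)cccc1F` carries a 2,6-difluorophenyl urea, and in a functional assay on HEK293 cells for agonist activity at Vasopressin V2 receptor (Homo sapiens), read by a luciferase reporter and cAMP accumulation (on this read-out lower numbers stand for an effect already at smaller amounts and higher numbers for an effect only at larger amounts of compound), compound 1 gives 82 nM. Compound 2 `Cc1cc(C(=O)N2CCCCc3ccccc32)ccc1CNC(=O)Nc1ccccc1F` carries a 2-fluorophenyl urea, and in this assay compound 2 gives 30 nM. Among the measured compounds shown here, of the two numbers measured so far, compound 2 stands lowest; compound 1 lies at a higher number, and that gap is beyond the usual scatter. For the measured compounds named here, no step between two measured compounds corresponds to the change now considered.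

Compound 3 `CCOC(=O)CNC(=O)NCc1ccc(C(=O)N2CCCCc3ccccc32)cc1C` is obtained from compound 2 by the change ((ethoxycarbonyl)methyl in place of 2-fluorophenyl on an amide-type nitrogen), an (ethoxycarbonyl)methyl in place of 2-fluorophenyl on an amide-type nitrogen. Going by the values given here, with no measured pair showing this kind of change, the expectation rests only on the value of compound 2 and the size of the change. The step from compound 2 to compound 3 is expected to go toward higher numbers, estimated at a 10-fold higher number from compound 2 to compound 3 (1.00 log units; beyond the scatter). For compound 3 the estimate in this assay is 300 nM, with a range from 60 nM to 3000 nM.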

Compound 3, half-maximal effective concentration: 140 nM
Compound 3: middle estimate off by 2.1-fold (0.33 log units), on the high side; the range from low to high includes it.
By their numbers in this assay, from the lowest: compound 2; then compounds 1 and 3 (each within the scatter of the next).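

At the amide-type nitrogen of the urea, both earlier compounds carried a fluorinated phenyl group, so they could not show whether a ring is needed there. In this assay the open-chain (ethoxycarbonyl)methyl group takes the place of 2-fluorophenyl with a 4.7-fold higher number from compound 2 to compound 3 (0.67 log units; beyond the scatter), which shows that a six-membered aromatic ring of carbon only on this nitrogen is not required for a measurable response, although the position is not indifferent to the change, since the step lies beyond the scatter. Nothing available on the properties of these compounds bears on this step, so it stands here without an explanation.

The single step removes the ring and the fluorine and brings in the ester together, so the compounds shown leave open which of these parts accounts for the higher number. From the compounds shown here alone, how a carboxylic acid in place of the ethyl ester, a plain alkyl chain without the ester, or a longer chain between the nitrogen and the ester would read in this assay also remains open.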